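Para-fluorine on the benzyloxime: a small step expected

The compounds below may be only part of what the source reports. "The series", "measured", "known", "first", "only" and "open" are said of these compounds alone.

Compound 1, `O/N=C1/C(c2c[nH]c3ccc(OCc4ccccc4)cc23)=Nc2ccc(OCc3ccccc3)cc21`: 17600 nM
Compound 2, `c1ccc(CO/N=C2/C(c3c[nH]c4ccccc34)=Nc3ccccc32)cc1`: 16900 nM

Both compounds were measured in a functional assay on SK-OV-3 cells (Homo sapiens) for cytotoxicity, read by MTT assay, with a stated time of 2 days; a lower number here means a stronger inhibitor, a higher number a weaker inhibitor. Compound 2 gives the lowest of the two numbers, but compound 1 lies so close to it that the two values are within the scatter and cannot be ordered.

Compound 3, `Fc1ccc(CO/N=C2/C(c3c[nH]c4ccccc34)=Nc3ccccc32)cc1`, differs from compound 2 by fluoro in place of hydrogen on an aromatic carbon. Among the compounds with values here, no measured pair shows this change, so the expectation rests on the two numbers alone: a step of a 1.1-fold lower number from compound 2 to compound 3 (0.05 log units; within the scatter) in this assay is expected, that is, none beyond the scatter.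

Compound 3 is therefore estimated at 15000 nM, within 6000 nM to 40000 nM.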

Compound 3, half-maximal inhibitory concentration: 29000 nM
Beside the measured number, compound 3's estimate is 1.9-fold (0.29 log units) below it; measured number inside the range.
By their numbers in this assay, from the lowest: compounds 2, 1 and 3 (each within the scatter of the next).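

Putting fluoro in place of hydrogen on this aromatic carbon, which turns benzyl into 4-fluorobenzyl, gives a 1.7-fold higher number from compound 2 to compound 3 (0.23 log units; within the scatter) in this assay and so cannot be told apart from no change. Within the data shown here, this is the first single-place step in the set, and it shows that this position accepts one added fluorine without a clear shift in the read-out.

On these data alone, whether a larger group here, such as an amine or a carboxylic acid, would move the number beyond the scatter remains open. Nothing measured among these compounds offers an explanation for the result.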